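Swapping Methyl for Chloro on the Shared Core

The compounds below may be only part of what the source reports. "The series", "measured", "known", "first", "only" and "open" are said of these compounds alone.

Compound 1 `Cc1ccc(C2CNN=C2S(=O)(=O)CC2=NCCS2)cc1` is one of three compounds tested in a functional assay, read by Griess assay, with a stated time of 150 min, tested at 100 ug/mL; a lower number here means a weaker effect, a higher number a stronger effect of the compound at the concentration tested. In this assay compound 1 gives 52.2%, the highest of the two numbers recorded. Its nearest neighbour is compound 3 `Cc1ccc(C2CNN=C2S(=O)(=O)CC2=NCCO2)cc1`, which in this assay gives 51.4%; the step of a number 0.8 percentage points lower from compound 1 to compound 3 (within the scatter) lies within the scatter, so the two compounds cannot be told apart on these numbers. Compound 2 `O=S(=O)(CC1=NCCS1)c1n[nH]cc1-c1ccc(Cl)cc1`, which carries a chloro group but sits on a different core, was reported in this assay as "not active" (no number reported), with no number given.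

Compound 4 `O=S(=O)(CC1=NCCS1)C1=NNCC1c1ccc(Cl)cc1` has not yet been measured in this assay. It differs from compound 1 in one place: chloro in place of methyl on an aromatic carbon. Within the data shown here, no measured step covers this exact change, and the only recorded step, from compound 1 to compound 3, concerns a different part of the molecule. The result for compound 2 shows that a chloro-bearing compound can be inactive, but its core differs too, so it gives no clean guide. Compound 4 is therefore expected to give about 40%, with a likely range from 10% to 60%; the expected step is a number 12.2 percentage points lower from compound 1 to compound 4 (beyond the scatter), leaning weaker but uncertain.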

Compound 4, a percentage reported as activity, at one concentration (the size of the read-out at that concentration, not a potency): "not active" (no number reported)
Compound 4: no number reported, and the estimate cannot be compared.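

In this assay, among these compounds, compound 1 gives 52.2% and compound 4 is reported as not active with no number, so no step between the two can be read. No available evidence bears on this result. The compounds shown leave open how large the difference between 4-methylphenyl and 4-chlorophenyl is on this core.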